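A few compounds are considered here, and "the series" means these few. Any claim that something is new, unique, unknown or untested is made for them only; others in the source may bear on it.

Three compounds of the series have been run so far in a functional assay on HepG2 cells (Homo sapiens) for inhibition, read by MTT assay, with a stated time of 72 h; on this read-out higher numbers stand for weaker inhibition and lower numbers for stronger inhibition. Compound 1 `C#CCSc1nc(N2CCN(C)CC2)c2ccncc2n1` reaches only the limit of this assay, > 80000 nM. Compound 2 `C#CCSc1nc(N2CCN(CC)CC2)c2ccncc2n1` likewise gives a limit, > 80000 nM. Compound 3 `CCSc1nc(Nc2cccc(OC)c2)c2ccncc2n1` stands on a core whose difference from that of compound 1 is not broken down here. In this assay compound 3 gives 10700 nM. The change from compound 1 to compound 2 is methyl in place of hydrogen on a saturated chain carbon bound to an amine nitrogen in a ring; its step in this assay, a step that the two limits leave unreadable from compound 1 to compound 2, cannot be sized because both values sit at the limit of > 80000 nM in this assay, at which 2 of the 3 values shown sit.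

Compound 4 `CCCSc1nc(Nc2cccc(OC)c2)c2ccncc2n1` is not yet measured. It differs from compound 3 by methyl in place of hydrogen on a saturated chain carbon, two bonds along the chain from a sulfur. The place is not that of the earlier change: there the methyl entered on a saturated chain carbon bound to an amine nitrogen in a ring, here on a saturated chain carbon two bonds along the chain from a sulfur, so the two are the same kind of change, not the same. No readable step of this kind is at hand. For compound 4 the expected step is a 1.2-fold lower number from compound 3 to compound 4 (0.08 log units; within the scatter), within the usual scatter, resting on compound 3 at 10700 nM as the nearest measured point. Compound 4 is therefore estimated at 9000 nM, between 4000 nM and 25000 nM.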

Compound 4, half-maximal inhibitory concentration: 17300 nM
Compound 4: middle estimate off by 1.9-fold (0.28 log units), on the low side, within the range that was stated.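

In this assay the methyl step reads a 1.6-fold higher number from compound 3 to compound 4 (0.21 log units; within the scatter), so on the core of compound 3 the change from ethylsulfanyl to propylsulfanyl leaves no difference that can be told from the scatter. For the compounds shown here, this is the only readable step of its kind, and it holds for this one place on this one core. It does not show that the methyl change carries over from one core to another, because the other methyl step, at a different place on the core of compound 1, has a limit at both ends and cannot be read: the limit of > 80000 nM in this assay, at which 2 of the 4 values shown sit.

From the compounds shown here alone, it remains open whether a longer chain, such as butylsulfanyl, or a chain bearing an amine or a carboxylic acid would give a step beyond the scatter on the core of compound 3. Going by these compounds, it also remains open whether any compound on the core of compound 1 gives a number rather than a limit, which a comparison of the same change on the two cores would require.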